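Series notes: lactam nitrogen substituent, step to compound 4

The source may hold more compounds than are shown below. What is called first, only, known or untested is meant among the compounds shown, and "the series" means these compounds.

Measured compounds in an assay on cell membranes (strain Dunkin Hartley) for displacement of a labelled ligand from Sigma non-opioid intracellular receptor 1 (Cavia porcellus), read by scintillation counting, with a stated time of 180 min; on this read-out lower numbers stand for stronger inhibition and higher numbers for weaker inhibition:
- compound 1 `CC1CCN(CCCOc2ccc3c(c2)N(Cc2ccccc2)C(=O)CC3)CC1`: 1.1 nM
- compound 2 `O=C1CCc2ccc(OCCCN3CCN(c4ccccc4)CC3)cc2N1Cc1ccccc1`: 341 nM
- compound 3 `Cc1ccc(CN2C(=O)CCc3ccc(OCCCN4CCC(C)CC4)cc32)cc1`: 1.49 nM

Compound 3 sits second highest of the three numbers in this assay. Its nearest neighbour is compound 1, separated by a 1.4-fold higher number from compound 1 to compound 3 (0.13 log units; within the scatter), a step that stays within the scatter. Among the measured compounds shown here, compound 2 is the furthest away; its value and that of compound 3 differ by a wide margin, beyond the scatter, and no single-point step connects them.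

Compound 4 `CC1CCN(CCCOc2ccc3c(c2)N(C)C(=O)CC3)CC1` is the next compound, not yet measured. It differs from compound 3 by hydrogen in place of 4-methylphenyl on a saturated chain carbon bound to an amide-type nitrogen in a ring, that is, 4-methylbenzyl to methyl on the amide-type nitrogen in the ring.

For the measured compounds named here, no measured step touches this position. Going by the values given here, the one measured step, from compound 1 to compound 3, concerns only a methyl on the aromatic ring of the benzyl group and is within the scatter, so it says nothing about removing the whole 4-methylphenyl. Among the compounds with values here, for compound 4 the step of a 5.4-fold higher number from compound 3 to compound 4 (0.73 log units; beyond the scatter) is therefore an estimate resting on no direct precedent, and a weakening beyond the scatter is expected rather than a gain. Compound 4 is estimated at 8 nM, with a range from 1.5 nM to 50 nM.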

Compound 4, inhibition constant: 40.2 nM
Compound 4: middle estimate off by 5.0-fold (0.70 log units), on the low side, within the range that was stated.
By their numbers in this assay, from the lowest: compounds 1 and 3 (each within the scatter of the next); then compound 4; then compound 2.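

In this assay, the change from 4-methylbenzyl to methyl on the amide-type nitrogen in the ring gives a 27-fold higher number from compound 3 to compound 4 (1.43 log units; beyond the scatter), and the same cut from compound 1 gives a 37-fold higher number from compound 1 to compound 4 (1.56 log units; beyond the scatter). Both steps are large, so among these compounds this position matters far more than the methyl on the aromatic ring of the benzyl group, whose step of a 1.4-fold higher number from compound 1 to compound 3 (0.13 log units; within the scatter) stays within the scatter. Nothing here accounts for the loss on going to methyl.

The compounds shown do not separate the contribution of the aromatic ring from that of the carbon chain: a cyclohexylmethyl or an n-butyl group on the same nitrogen would address this, while a phenethyl group would test the length of the link to the ring. On these data alone, it also remains open whether the same cut costs as much with the side-chain amine of compound 2, since the steps above all carry the 4-methylpiperidine-bearing chain of compound 1.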